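The compounds below may be only part of what the source reports. "The series", "measured", "known", "first", "only" and "open" are said of these compounds alone.

Measured compounds in an assay for inhibition of 15-hydroxyprostaglandin dehydrogenase [NAD(+)] (Homo sapiens), read by fluorescence, with a stated time of 15 min, in the presence of a further agent that is not named here; on this read-out higher numbers stand for weaker inhibition and lower numbers for stronger inhibition:
- compound 1, `CCC[S+]([O-])c1sc2nc(-c3cccs3)cc(-c3ccccc3)c2c1N`, gives 2.1 nM
- compound 2, `Nc1c([S+]([O-])CCCCl)sc2nc(-c3cccs3)cc(-c3ccccc3)c12`, gives 4 nM
- compound 3, `Nc1c(C(=O)O)sc2nc(-c3cccs3)cc(-c3ccccc3)c12`, gives only a limit, > 7500 nM

Compound 1 and compound 2 share the core and differ only in the chain: a 1.9-fold higher number from compound 1 to compound 2 (0.28 log units; within the scatter). Compound 3 stands apart. Its value is a limit of this assay and not a number (the limit of > 7500 nM in this assay, at which 1 of the 3 values shown sits), and both steps into it are large: an at least 3500-fold higher number from compound 1 to compound 3 (3.55 log units; beyond the scatter) and an at least 1800-fold higher number from compound 2 to compound 3 (3.27 log units; beyond the scatter). Among the three measured compounds, compound 3 is the weakest inhibitor shown, since both steps to it lie beyond the scatter.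

Compound 4, `CCCCSc1sc2nc(-c3cccs3)cc(-c3ccccc3)c2c1N`, is unmeasured. It differs from compound 3 in one place: butylsulfanyl in place of carboxy on an aromatic carbon. The change runs the other way from the two large measured steps, an at least 3500-fold higher number from compound 1 to compound 3 (3.55 log units; beyond the scatter) and an at least 1800-fold higher number from compound 2 to compound 3 (3.27 log units; beyond the scatter), in which a carboxy on this aromatic carbon replaced a sulfur-bearing chain and this assay recorded only a limit. Replacing the carboxy with butylsulfanyl is therefore expected to bring the number back down sharply, toward the level of compound 1 and compound 2. The expected step is an at least 1500-fold lower number from compound 3 to compound 4 (3.17 log units; beyond the scatter). Compound 4 is expected to give about 5 nM in this assay, with a range from 1.5 nM to 25 nM.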

Compound 4, half-maximal inhibitory concentration: > 80 nM
Compound 4: a limit, no number; the forecaster's own chance of this, stated with the estimate: 5%; middle value at least 16-fold (1.20 log units) from the limit.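

In this assay compound 4 gives a limit and not a number: the limit of > 80 nM in this assay, at which 1 of the 4 values shown sits. The earlier compounds shown here showed only that a carboxy on this aromatic carbon and a sulfur-bearing chain with oxygen on the sulfur lie far apart, whereas this result shows that a sulfur-bearing chain here does not by itself bring the low numbers of compound 1 and compound 2, with an at least 38-fold higher number from compound 1 to compound 4 (1.58 log units; beyond the scatter) and an at least 20-fold higher number from compound 2 to compound 4 (1.30 log units; beyond the scatter). From the compounds shown here alone, the step between compound 3 and compound 4 cannot be read, as both values are limits, so the butylsulfanyl-for-carboxy change has no measured size and even its direction stays unknown.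

The butylsulfanyl chain differs from the chains of compound 1 and compound 2 in two ways at once, in its length and in the missing oxygen on sulfur, and the compounds shown do not separate these two. A propylsulfanyl chain, or a butyl chain with oxygen on the sulfur, on this same aromatic carbon would show which of the two carries the gap.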